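A pyridyl in place of a tolyl on a shared core

The source may report more compounds than this note shows. Statements on the series, on what has been measured and on what is new or still open speak of the compounds shown alone.

For the measured compounds named here, of the two numbers measured so far in a functional assay on DU-145 cells (Homo sapiens) for cytotoxicity, in the presence of a further agent that is not named here (on this read-out higher numbers stand for weaker inhibition and lower numbers for stronger inhibition), compound 2 `Cc1ccc(-c2cc(-c3ccc(Cl)o3)cc(-c3ccsc3)n2)cc1` is placed at the top, yet the gap to its nearest neighbour is within the scatter; in this assay compound 2 gives 21200 nM. That neighbour is compound 1 `Clc1ccc(-c2cc(-c3ccsc3)nc(-c3ccccc3Cl)c2)o1`, and in this assay compound 1 gives 19300 nM. Compound 3 `Clc1ccc(-c2cc(-c3ccsc3)nc(-c3ccccn3)c2)o1` differs from compound 2 by pyridin-2-yl in place of 4-methylphenyl on an aromatic carbon. Going by the values given here, the only measured step concerns the same position: a 1.1-fold higher number from compound 1 to compound 2 (0.04 log units; within the scatter), an exchange of one six-membered carbon ring for another that stayed within the scatter. Among the compounds with values here, no measured step introduces a ring nitrogen at this position, so that part of the change is untested. On this basis compound 3 is expected to sit close to compound 2, the step of a 1.1-fold lower number from compound 2 to compound 3 (0.03 log units; within the scatter) being estimated to remain within the scatter. Compound 3 is therefore estimated at 20000 nM, in the range 8000 nM to 50000 nM.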

Compound 3, half-maximal inhibitory concentration: 10900 nM
The estimate for compound 3 lay 1.8-fold (0.26 log units) above the measured number, within the range that was stated.
By their numbers in this assay, from the lowest: compounds 3, 1 and 2 (each within the scatter of the next).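

In this assay, pyridin-2-yl brings a ring nitrogen to this position for the first time among the compounds shown, yet the exchange for 4-methylphenyl stays within the scatter (a 1.9-fold lower number from compound 2 to compound 3 (0.29 log units; within the scatter)), as does the exchange for 2-chlorophenyl (a 1.8-fold lower number from compound 1 to compound 3 (0.25 log units; within the scatter)). The three six-membered aromatic rings tested on this aromatic carbon next to the ring nitrogen therefore cannot be told apart, even though only pyridin-2-yl carries a hydrogen-bond acceptor. Nothing available accounts for how closely these numbers agree.

The compounds shown leave open whether pyridin-3-yl, pyridin-4-yl or a ring bearing an amine or a carboxylic acid would move the number beyond the scatter at this position. They also leave open how the number responds to exchanging the 5-chlorofuran-2-yl or thiophen-3-yl group.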